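A few compounds are considered here, and "the series" means these few. Any claim that something is new, unique, unknown or untested is made for them only; others in the source may bear on it.

Three compounds of the series carry numbers in an assay on isolated protein for inhibition of Polyunsaturated fatty acid 5-lipoxygenase (Homo sapiens), read by ELISA, with a stated time of 10 min; a lower number here means a stronger inhibitor, a higher number a weaker inhibitor. Compound 1, `COC1=CC(=O)C=C(Br)C1=O`, gives 1670 nM. Compound 2, `CCCCCc1cc(O)cc(OC)c1O`, gives 940 nM. Compound 3, `CCCCCCCCCCCCCc1cc(OC(C)=O)cc(OC)c1OC(C)=O`, gives 1020 nM. Compound 3 holds the second highest of the three numbers; its nearest neighbour is compound 2, a gap within the scatter, and its furthest is compound 1, a gap that also lies within the scatter. Among the measured compounds shown here, no pair of measured compounds differs in one place only, so the numbers carry no isolated single step.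

Compound 4, `CCCCCc1cc(OC(C)=O)cc(OC)c1OC(C)=O`, is the next member. Against compound 3 the difference is hydrogen in place of octyl on a saturated chain carbon, five bonds along the chain from an aromatic carbon. Compound 2 shares the shorter chain of compound 4 but differs from it elsewhere in the molecule, so its number is only a loose guide. All three measured numbers sit within the scatter of one another, and the chain change is therefore expected to move the number little, with no clear direction beyond the scatter. For compound 4 the expected step from compound 3 is a 1.2-fold higher number from compound 3 to compound 4 (0.07 log units; within the scatter), expected to stay within the scatter. Compound 4 is estimated at 1200 nM, with a range from 500 nM to 3000 nM.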

Compound 4, half-maximal inhibitory concentration: 1090 nM
Beside the measured number, compound 4's estimate is 1.1-fold (0.04 log units) above it; low and high end bracket the measured number.
By their numbers in this assay, from the lowest: compounds 2, 3, 4 and 1 (each within the scatter of the next).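

In this assay, among the compounds shown here, this is the first pair that differs in one place only, and it reads a 1.1-fold higher number from compound 3 to compound 4 (0.03 log units; within the scatter), so the two numbers stand within the scatter of each other. Hydrogen in place of octyl on a saturated chain carbon, five bonds along the chain from an aromatic carbon, therefore gives no separation in the read-out for this pair, with the rest of the molecule held constant; the earlier compounds could not show this, as none of them formed such a pair. No measured information bears on why the number stays put across this change.

What this single pair leaves open is whether the same holds for a longer chain than that of compound 3, or for a chain ending in a carboxylic acid or an amine. It also leaves open how the free hydroxyl groups, the methoxy group and the acetyl ester groups each bear on the number, as no pair shown isolates any of them in one place.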